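Replacing a pyridin-2-yl group on an oxadiazole core

A few compounds are considered here, and "the series" means these few. Any claim that something is new, unique, unknown or untested is made for them only; others in the source may bear on it.

Measured compounds:
- compound 1, `Cc1cccc(-c2noc([C@H](C)NC(=O)c3cc(C4CC4)nn3C)n2)c1`: 167 nM
- compound 2, `C[C@H](NC(=O)c1cc(C(F)(F)F)nn1C)c1nc(-c2ccccn2)no1`: > 30000 nM

Of the compounds shown here, two have been measured in an assay on T-REx-293 cells for inhibition of potassium channel subfamily T member 1 (Homo sapiens), read by patch clamp; on this read-out lower numbers stand for stronger inhibition and higher numbers for weaker inhibition. Compound 1 gives 167 nM. For compound 2 the assay reports only a limit, > 30000 nM, so no number is known for it; this is where it stands, at the limit of > 30000 nM in this assay, at which 1 of the 2 values shown sits, and it is the weaker of the two on the numbers shown.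

Compound 3, `CO[C@H](C)c1cc(-c2noc([C@H](C)NC(=O)c3cc(C(F)(F)F)nn3C)n2)ccn1`, has not yet been measured. It keeps the trifluoromethyl-bearing amide portion of compound 2 and changes the group on the oxadiazole: a group of 10 heavy atoms (8 carbon, 1 nitrogen, 1 oxygen; one six-membered aromatic ring with 1 hetero atom) in place of a group of 6 heavy atoms (5 carbon, 1 nitrogen; one six-membered aromatic ring with 1 hetero atom), on an aromatic carbon.

Going by the values given here, no step between measured compounds exists that shares exactly this change, so the size of the step from compound 2 to compound 3 cannot be read off. Because compound 2 sits at the limit (the limit of > 30000 nM in this assay, at which 1 of the 2 values shown sits), any measurable value for compound 3 would be a move toward stronger inhibition. The expected step is an at least 15-fold lower number from compound 2 to compound 3 (1.17 log units; beyond the scatter), in that direction. Compound 3 is estimated at 2000 nM, within a range from 200 nM to 20000 nM, with a real chance that only a limit is returned again.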

Compound 3, half-maximal inhibitory concentration: 778 nM
Compound 3: middle estimate off by 2.6-fold (0.41 log units), on the high side; measured number inside the range.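

With the trifluoromethyl-bearing amide portion held fixed, replacing the pyridin-2-yl group with a larger group that also holds one six-membered aromatic ring with 1 hetero atom, plus one defined stereocentre, gives an at least 38-fold lower number from compound 2 to compound 3 (1.58 log units; beyond the scatter) in this assay. The group on this aromatic carbon of the core, between two ring nitrogen atoms, can therefore decide on its own whether this amide gives a measurable value, something the first two compounds could not show because they differ in more than one place. The true size of the step remains unknown, and the printed figure is only a bound because compound 2 has a limit rather than a number: the limit of > 30000 nM in this assay, at which 1 of the 3 values shown sits.

The entering group differs from pyridin-2-yl in several features at once, so the compounds shown do not reveal which feature accounts for the stronger inhibition. They also leave open what a simpler substituent on the pyridine ring, such as an amine or a plain ethyl chain, would give, and whether the opposite configuration at the new stereocentre would give a similar value.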